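A few compounds are considered here, and "the series" means these few. Any claim that something is new, unique, unknown or untested is made for them only; others in the source may bear on it.

Measured so far in a toxicity assay on the whole organism (strain Icem-CET (SPF Caw)) for cytotoxicity, with Mus musculus as the target; a higher number here means that more compound is needed for the effect, a lower number that less compound is needed:

Compound 1, `C/C(C(=O)NC1CC1)=C(/C)c1ccc(Br)cc1`: 100 mg/kg
Compound 2, `COc1ccc(/C(C)=C(\C)C(=O)NC2CC2)cc1`: 250 mg/kg

Going by the values given here, compound 2 stands highest of the two numbers in this assay; the single measured step, a 2.5-fold higher number from compound 1 to compound 2 (0.40 log units; beyond the scatter), is modest but beyond the scatter. Compound 3, `C/C(C(=O)NC1CC1)=C(/C)c1ccc(Cl)cc1`, differs from compound 2 by chloro in place of methoxy on an aromatic carbon. The step of a 2.5-fold higher number from compound 1 to compound 2 (0.40 log units; beyond the scatter) bears on this change: there a halogen left and methoxy entered, here methoxy leaves and a halogen enters, so a step of similar size in the opposite direction is expected, a 2.3-fold lower number from compound 2 to compound 3 (0.36 log units; beyond the scatter). Compound 3 is therefore estimated at 110 mg/kg in this assay, within 60 mg/kg to 220 mg/kg.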

Compound 3, dose for half-maximal effect: 350 mg/kg
Estimate against measurement, compound 3: 3.2-fold (0.50 log units) below, outside the stated range (above it).
By their numbers in this assay, from the lowest: compound 1; then compounds 2 and 3 (each within the scatter of the next).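

In this assay chloro and methoxy on this aromatic carbon, para to a large group, are not separated (a 1.4-fold higher number from compound 2 to compound 3 (0.15 log units; within the scatter)). The two halogens do not read as one class here: chloro in place of bromo gives a modest step (a 3.5-fold higher number from compound 1 to compound 3 (0.54 log units; beyond the scatter)), so bromo alone stands apart among the three groups. No measured property bears on this result, so no cause can be assigned.

Open, on these data alone, is how fluoro, an amine or a carboxylic acid would read at this position. Also open, as far as these compounds go, is whether the bromo difference holds on another core.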